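Swapping Chloro for Fluoro on a Hemolysis Read-out

The source may report more compounds than this note shows. Statements on the series, on what has been measured and on what is new or still open speak of the compounds shown alone.

Of the compounds shown here, two have been measured for their effect on red blood cells. In an ADME assay on cells (Erythrocyte, Homo sapiens) for activation, read by hemolysis, with a stated time of 30 min, tested at 2.5 mM (a higher number here means a stronger effect of the compound at the concentration tested, a lower number a weaker effect), compound 1, `N=C(N)c1ccc(-c2ccc(-c3ccc(Cl)cc3)s2)s1`, gives 14.3%. Compound 2, `COc1ccc(-c2ccc(-c3ccc(C(=N)N)o3)o2)cc1`, gives 8.1% in this assay. Compound 1 has the higher of these two numbers, but its gap to compound 2 lies within the usual scatter, so the two cannot be told apart on this basis.

The next compound, compound 3, `N=C(N)c1ccc(-c2ccc(-c3ccc(F)cc3)s2)s1`, differs from compound 1 in one place: fluoro in place of chloro on an aromatic carbon. One small group is exchanged for another on the six-membered aromatic ring of carbon only, and nothing else changes. Among the compounds with values here, no measured pair in this set differs by such an exchange, so there is no measured step to lean on. Within the data shown here, the only measured comparison, between compound 1 and compound 2, stays within the scatter. The step of a number 3.3 percentage points lower from compound 1 to compound 3 (within the scatter) in this assay is therefore expected to be small, with no clear direction beyond the scatter. Compound 3 is estimated to give 11% in this assay, with a likely range from 3% to 22%.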

Compound 3, a percentage reported as activity, at one concentration (the size of the read-out at that concentration, not a potency): 14%
Beside the measured number, compound 3's estimate is 3 percentage points below it; the measured number falls inside the stated range.
By their numbers in this assay, from the lowest: compounds 2, 3 and 1 (each within the scatter of the next).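

Within the data shown here, the exchange of chloro for fluoro now has a measured size at this position, the aromatic carbon para to a large group on the six-membered aromatic ring of carbon only: in this assay it gives a number 0.3 percentage points lower from compound 1 to compound 3 (within the scatter), the first step in this set that changes a single place. Compound 1 and compound 3 therefore cannot be told apart in this read-out, so at this position, on this core and at the one concentration tested, chloro and fluoro are interchangeable as far as the data can show, something the earlier comparison could not reveal because compound 1 and compound 2 differ in more than one place. Nothing measured here explains why the two compounds behave alike, so the result stands as an observation only.

On these data alone, this single exchange covers just two small groups, so it remains open whether a group of another kind at the same position, such as an amine or a carboxylic acid, would also stay within the scatter of compound 1. As far as these compounds go, it is equally open whether the same exchange would give a similar result on a different core, such as that of compound 2.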